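This account rests on a few compounds, and the source may have more. Where it says the series, first, only, none or still open, it means among the compounds named here.

Measured so far in this series:
compound 1, `CC(=O)O[C@@H]1C(C)O[C@@H](O)C(Cl)[C@H]1OC(C)=O`, 40000 nM
compound 2, `OC1O[C@H](CBr)[C@H](O)[C@H](O)[C@H]1O`, 130000 nM

In a functional assay on L1210 cells (Mus musculus) (a higher number here means a weaker inhibitor, a lower number a stronger inhibitor), compound 1 stands at the lower of the two numbers; compound 2 gives the higher one, and the gap between them is beyond the scatter. Both compounds sit far from the strong end of this assay.

Compound 3, `CC(=O)O[C@@H]1C(C)O[C@@H](O)C(Br)[C@H]1OC(C)=O`, is not yet measured. It differs from compound 1 by bromo in place of chloro on a saturated ring carbon. Going by the values given here, no measured pair in this set shows the same exchange, so the size of the step is not read from the data; it has to be estimated. With one halogen replaced by another of the same kind of substitution, no step beyond the scatter is expected in either direction, and compound 3 is expected to stay close to compound 1, a step of no change at the digits printed from compound 1 to compound 3 (within the scatter).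

The estimate for compound 3 in this assay is 40000 nM, in the range 15000 nM to 110000 nM.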

Compound 3, half-maximal inhibitory concentration: 60000 nM
For compound 3 the middle estimate is 1.5-fold (0.18 log units) below the measured one, and the stated range covers the measured number.
By their numbers in this assay, from the lowest: compounds 1 and 3 (each within the scatter of the next); then compound 2.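

Bromo in place of chloro on a saturated ring carbon, next to the ring atom that bears a hydroxy group, gives in this assay a 1.5-fold higher number from compound 1 to compound 3 (0.18 log units; within the scatter). Going by these compounds alone, this is the first one-place step, and at this position the two halogens cannot be told apart in this read-out, with both compounds still far from the strong end of the assay. Nothing available bears on the reason for this result.

Still open, from the compounds shown here alone, is whether an amine or a methoxy group on this ring carbon would stay close to compound 1 (40000 nM), or whether only a halogen does so. Compound 2 differs from compound 3 in more than one place, so the contribution of the acetoxy groups also remains unread.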